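Swapping a fluorinated ring for a plain chain on the amide

The compounds below may be only part of what the source reports. "The series", "measured", "known", "first", "only" and "open" are said of these compounds alone.

Measured compounds:
- compound 1, `O=C(Nc1ccc(OC(F)(F)F)cc1)NC1CCN(C(=O)[C@@H]2CCOC2)CC1`: 23 ug/mL
- compound 2, `CCOC(=O)N1CCC(NC(=O)Nc2ccc(OC(F)(F)F)c(F)c2)CC1`: 0.35 ug/mL
- compound 3, `O=C(Nc1ccc(C(F)(F)F)c(F)c1)NC1CCN(C(=O)C2(C(F)(F)F)CC2)CC1`: 0.08 ug/mL

In a physicochemical assay for solubility, read by mass spectrometry, in phosphate buffer, with a stated time of 24 h, at pH 7.4 (on this read-out lower numbers stand for lower solubility and higher numbers for higher solubility), compound 3 gives the lowest number of the three. Its nearest neighbour is compound 2, whose value is beyond the usual scatter above it, and compound 1 stands far above both. All three compounds share a urea linked to a piperidine carrying an acyl or carbamate group, and they differ in the aryl substituents and in that group on the carbonyl carbon.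

Compound 4, `CC[C@H](C)C(=O)N1CCC(NC(=O)Nc2ccc(C(F)(F)F)c(F)c2)CC1`, has not yet been measured. It keeps the aryl part of compound 3 and changes only the group on the carbonyl carbon: sec-butyl in place of 1-(trifluoromethyl)cyclopropyl on a carbonyl carbon. The group that leaves carries fluorine and a small ring; the group that enters is an unbranched-to-branched carbon chain with no ring and no fluorine.

Going by the values given here, no measured pair shows this exact change, so the expectation rests on the spread of values seen here. A modest rise in this assay is expected, so the step of a 3.8-fold higher number from compound 3 to compound 4 (0.57 log units; beyond the scatter) is estimated upward but well short of the gap to compound 1. Compound 4 is therefore expected to give about 0.3 ug/mL, within a range from 0.08 ug/mL to 1.2 ug/mL.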

Compound 4, solubility: 0.46 ug/mL
Estimate against measurement, compound 4: 1.5-fold (0.19 log units) below; measured number inside the range.
By their numbers in this assay, from the lowest: compound 3; then compounds 2 and 4 (each within the scatter of the next); then compound 1.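

Compound 3 and compound 4 differ in one place only, so this pair isolates the group on the carbonyl carbon while the aryl part stays the same. In this assay the change from 1-(trifluoromethyl)cyclopropyl to sec-butyl gives a 5.8-fold higher number from compound 3 to compound 4 (0.76 log units; beyond the scatter) and shows that the read-out responds to a change at this position. No measurement shown here accounts for the rise.

The swap removes the three-membered ring and the fluorine together, so this single step cannot separate the two, and a plain cyclopropyl or a 2,2,2-trifluoroethyl group on the same carbonyl carbon would be needed to tell them apart. Going by these compounds, how a carboxylic acid or an amine on the chain would read at this position also remains open.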